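Five-membered ring swap on the chlorinated arm of compound 2

A few compounds are considered here, and "the series" means these few. Any claim that something is new, unique, unknown or untested is made for them only; others in the source may bear on it.

Measured so far:
compound 1 `Cn1nc2c(=O)n(CC3(O)CCN(Cc4ccc(-c5ccco5)cc4Cl)CC3)cnc2c1-c1ccc(C2(N)CC2)cc1` — 66.1 nM
compound 2 `Cn1nc2c(=O)n(CC3(O)CCN(Cc4ccc(-c5cccs5)cc4Cl)CC3)cnc2c1-c1ccc(CN)cc1` — 38.6 nM
compound 3 `CCNCc1ccc(-c2c3ncn(CC4(O)CCN(Cc5ccc(-c6ccco6)cc5Cl)CC4)c(=O)c3nn2C)cc1` — 15.2 nM

In an assay on isolated protein for inhibition of ubiquitin carboxyl-terminal hydrolase 7 (Homo sapiens), with stated times of 30 min and 2 h (a lower number here means a stronger inhibitor, a higher number a weaker inhibitor), compound 2 gives 38.6 nM, the second highest of the three numbers. Its nearest neighbour is compound 1, whose number is higher but within the scatter; compound 3 gives a lower number, beyond the scatter. Among the compounds with values here, the only single-point step in the set is a 4.3-fold lower number from compound 1 to compound 3 (0.64 log units; beyond the scatter), which concerns the amine-bearing group on the other aryl ring, not the five-membered ring on the chlorinated arm. Compound 1 and compound 2 differ in two places at once, so their values give no clean reading of a ring swap alone.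

Compound 4 `Cn1nc2c(=O)n(CC3(O)CCN(Cc4ccc(-n5cccn5)cc4Cl)CC3)cnc2c1-c1ccc(CN)cc1` differs from compound 2 by 1H-pyrazol-1-yl in place of thiophen-2-yl on an aromatic carbon. Within the data shown here, no measured step in this set bears on such a change, so the step is judged only from the spread of the series: compound 1, compound 2 and compound 3 all sit within a narrow band, and the change is a like-for-like swap of one five-membered aromatic ring for another. No step beyond the scatter is expected in this assay in either direction. Compound 4 is therefore estimated at 45 nM, with a range of 18 nM to 110 nM. This expectation amounts to a 1.2-fold higher number from compound 2 to compound 4 (0.07 log units; within the scatter), within the scatter.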

Compound 4, half-maximal inhibitory concentration: 233 nM
Beside the measured number, compound 4's estimate is 5.2-fold (0.71 log units) below it, and the stated range ends below it.
By their numbers in this assay, from the lowest: compound 3; then compounds 2 and 1 (each within the scatter of the next); then compound 4.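

In this assay, the position para to a large group and meta to a chloro group does not treat all five-membered aromatic rings alike: a 6.0-fold higher number from compound 2 to compound 4 (0.78 log units; beyond the scatter). The swap keeps the ring size and the count of 5 heavy atoms, with no net charge and no hydrogen-bond donors on either side, so these shared features alone do not keep the number within the scatter; what does differ is the atoms, with sulfur leaving, two nitrogens entering and hydrogen-bond acceptors rising from 1 to 2. No supporting measurement in hand bears on the origin of this step.

Thiophen-2-yl and 1H-pyrazol-1-yl differ at once in their hetero atoms and in the ring atom that carries the link, a ring carbon in one and a ring nitrogen in the other, so this single pair cannot separate the two changes. A 1H-pyrazol-4-yl or a thiazol-2-yl ring on the aminomethyl-bearing scaffold of compound 2 would address that question, and a furan-2-yl ring there would show whether an oxygen-containing ring tracks with thiophen-2-yl or with 1H-pyrazol-1-yl.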